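Replacing fluoro with methoxycarbonyl: compound 3 to compound 4

The compounds below may be only part of what the source reports. "The series", "measured", "known", "first", "only" and "open" are said of these compounds alone.

In a functional assay on KB 3-1 cells (Homo sapiens) for cytotoxicity, read by MTT assay, with a stated time of 68 h (a higher number here means a weaker inhibitor, a lower number a stronger inhibitor), three compounds with different groups on a shared core have been measured. Compound 3 (`O=C(Nc1cccc(-c2ccc(F)cc2)c1)C(Cl)Cl`) gives 26200 nM. Compound 1 (`O=C(Nc1cccc(-c2ccccc2C(F)(F)F)c1)C(Cl)Cl`) gives 35900 nM, so these two values lie within the scatter of each other. Compound 2 (`Cc1ccc(-c2cccc(NC(=O)C(Cl)Cl)c2)cc1`) returns > 50000 nM, which is a limit of the assay and not a number. Compound 3 therefore stands level with compound 1, and only these two have numbers.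

Compound 4 (`COC(=O)c1ccc(-c2cccc(NC(=O)C(Cl)Cl)c2)cc1`) carries methoxycarbonyl in place of fluoro on an aromatic carbon, para to a large group: methoxycarbonyl in place of fluoro on an aromatic carbon. Among the compounds with values here, one measured step bears on this change: an at least 1.9-fold lower number from compound 2 to compound 3 (0.28 log units; that floor lies within the scatter), with fluoro in place of methyl on an aromatic carbon. Going by these compounds, one end of that step is a limit, so its true size remains unknown. No measured step here is shown to lie beyond the scatter, so no step beyond it is expected in this assay, although compound 4 could also end at the limit. The estimated change, a 1.1-fold higher number from compound 3 to compound 4 (0.06 log units; within the scatter), is expected to stay within the scatter. For compound 4 the estimate is 30000 nM, with an expected range of 13000 nM to 50000 nM.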

Compound 4, half-maximal inhibitory concentration: > 50000 nM
Compound 4 was reported as a limit; the forecaster's own chance of this, stated with the estimate: 35%; middle value at least 1.6-fold (0.22 log units) from the limit.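

Compound 4 gives > 50000 nM, which is a limit of the assay and not a number. Methoxycarbonyl in place of fluoro, on an aromatic carbon para to a large group, gives an at least 1.9-fold higher number from compound 3 to compound 4 (0.28 log units; that floor lies within the scatter), so the change cannot be shown to exceed the scatter, and its true size remains unknown. The step from compound 2 to compound 4 cannot be read, and this position now holds two groups, methyl and methoxycarbonyl, that end at a limit, with fluoro the only group there that has a number, which leaves the readings at this position bounded by a single assay ceiling: the limit of > 50000 nM in this assay, at which 2 of the 4 values shown sit.

The compounds shown leave open how far methyl and methoxycarbonyl truly lie from fluoro in this assay, and whether any group at this position moves the number beyond the scatter from compound 3, in either direction. A carboxylic acid, an amine or a chlorine on the same aromatic carbon could show whether a value below the limit is common at this position or whether fluoro stands alone there.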